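This account rests on a few compounds, and the source may have more. Where it says the series, first, only, none or still open, it means among the compounds named here.

For the measured compounds named here, compound 2 `CCO/C(O)=C1\C(COCCn2cc(N)nc2O)=NC(C)=C(C(=O)OC)C1c1ccccc1Cl` has the highest of the two numbers so far in a functional assay (aorta) with Rattus norvegicus as the target; a lower number here means a stronger inhibitor, a higher number a weaker inhibitor: in that assay compound 2 gives 31.6 nM. Its nearest neighbour is compound 1 `CCO/C(O)=C1\C(COCCn2ccnc2C)=NC(C)=C(C(=O)OC)C1c1ccccc1Cl`, which in this assay gives 2.51 nM; the step of a 13-fold higher number from compound 1 to compound 2 (1.10 log units; beyond the scatter) is large and beyond the scatter. Compound 3 `CCO/C(O)=C1\C(COCCn2c(N)cnc2O)=NC(C)=C(C(=O)OC)C1c1ccccc1Cl` differs from compound 2 only in the arrangement of the same atoms: 5-amino-2-hydroxy-1H-imidazol-1-yl in place of 4-amino-2-hydroxy-1H-imidazol-1-yl on a saturated chain carbon, two bonds along the chain from an oxygen on a saturated carbon. Going by the values given here, no measured step bears directly on this change; the one step known, from compound 1 to compound 2, swaps the whole substituent pattern of the five-membered ring rather than moving the amino group within it, so it gives no direction. For compound 3 a step within the scatter is therefore expected in this assay, a 1.1-fold lower number from compound 2 to compound 3 (0.02 log units; within the scatter). Compound 3 is estimated at 30 nM, with a range from 10 nM to 100 nM.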

Compound 3, half-maximal inhibitory concentration: 158 nM
Beside the measured number, compound 3's estimate is 5.3-fold (0.72 log units) below it; the measured number lies above the stated range.
By their numbers in this assay, from the lowest: compound 1; then compound 2; then compound 3.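

Moving the amino group alone matters at this position: with the same atoms in the ring, 5-amino-2-hydroxy-1H-imidazol-1-yl in place of 4-amino-2-hydroxy-1H-imidazol-1-yl gives a clear change in this assay (a 5.0-fold higher number from compound 2 to compound 3 (0.70 log units; beyond the scatter)), so the arrangement of the groups on the ring counts here, not only their identity. Measured against 2-methyl-1H-imidazol-1-yl, the loss with the 5-amino isomer is wider still (a 63-fold higher number from compound 1 to compound 3 (1.80 log units; beyond the scatter)), and both amino-hydroxy isomers are weaker inhibitors than compound 1. Nothing available explains the gap between the two isomers.

On these data alone, it remains open whether the amino group or the hydroxy group carries the gap to compound 1; no ring here holds only one of them. Also open, as far as these compounds go, is how a carboxylic acid in place of the amino group, or a longer chain in place of the ethyl link, would read.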